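Halogen on the pendant phenyl of the aminothiophene ketone series

The compounds below may be only part of what the source reports. "The series", "measured", "known", "first", "only" and "open" are said of these compounds alone.

Measured so far in a functional assay on CHO cells for agonist activity at adenosine receptor A1 (Homo sapiens), read by fluorescence and ERK phosphorylation, with stated times of 30 min and 1.5 h, tested at 10 uM; on this read-out higher numbers stand for a stronger effect at the one concentration tested and lower numbers for a weaker effect:
compound 1, `Nc1scc(-c2ccccc2)c1C(=O)c1ccc(Cl)cc1`, gives 64%;
compound 2, `Nc1scc(-c2cccc(Cl)c2)c1C(=O)c1ccc(Cl)cc1`, gives 75%;
compound 3, `Nc1scc(-c2cccc(Br)c2)c1C(=O)c1ccc(Cl)cc1`, gives 69%.

Compound 3 sits second of the three numbers. Its nearest neighbour is compound 1, whose value is lower by a number 5 percentage points higher from compound 1 to compound 3 (within the scatter), and its furthest is compound 2, from which it differs by a number 6 percentage points lower from compound 2 to compound 3 (within the scatter); both of these steps lie within the scatter, so the three measured compounds are not separated from one another by this read-out.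

Compound 4, `Nc1scc(-c2ccc(I)cc2)c1C(=O)c1ccc(Cl)cc1`, is not yet measured. Relative to compound 3 the change is 4-iodophenyl in place of 3-bromophenyl on an aromatic carbon.

Going by the values given here, two measured steps bear on it. The step of a number 5 percentage points higher from compound 1 to compound 3 (within the scatter) shows what adding bromo to the phenyl did, and the step of a number 6 percentage points lower from compound 2 to compound 3 (within the scatter) shows the exchange of one halogen for another; neither was beyond the scatter. Among the compounds with values here, only the step of a number 11 percentage points higher from compound 1 to compound 2 (beyond the scatter) was beyond the scatter, and it concerns chloro, not the iodo of compound 4. Within the data shown here, no measured pair covers the move to a 4-iodophenyl, so the expectation for compound 4 rests on the observation that halogen changes on this ring have so far stayed within the scatter. The expected step is a number 1 percentage points lower from compound 3 to compound 4 (within the scatter), with no change beyond the scatter anticipated.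

Compound 4 is therefore estimated at 68%, in the range 55% to 80%.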

Compound 4, a percentage reported as activity, at one concentration (the size of the read-out at that concentration, not a potency): 61%
Beside the measured number, compound 4's estimate is 7 percentage points above it, within the range that was stated.
By their numbers in this assay, from the lowest: compounds 4, 1, 3 and 2 (each within the scatter of the next, the first and the last beyond it).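

Going by these compounds alone, compound 4 is the first member with a 4-iodophenyl at this place, and in this assay iodo in place of hydrogen stays within the scatter of the plain phenyl, as the step of a number 3 percentage points lower from compound 1 to compound 4 (within the scatter) shows. The exchange against the 3-bromophenyl also stays within it, at a number 8 percentage points lower from compound 3 to compound 4 (within the scatter), whereas the exchange against the 3-chlorophenyl is the second step in the set to pass beyond it, at a number 14 percentage points lower from compound 2 to compound 4 (beyond the scatter), so compound 2 now stands apart from both compound 1 and compound 4, while compound 3 stands apart from none. Both exchanges alter the halogen and its place on the phenyl at once, so these values cannot say which of the two matters, and nothing at hand offers a reason for either step.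

Open, going by these compounds, is how one and the same halogen behaves when only its place on the phenyl changes, and how this position responds to a group other than a halogen, such as a methoxy, an amine or a carboxylic acid. Also open, on these data alone, is whether these differences, all read at a single concentration as a stronger or weaker effect there, hold at other concentrations.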